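The compounds below may be only part of what the source reports. "The series", "measured", "known", "first", "only" and "open" are said of these compounds alone.

Compound 1: `Cc1ccccc1CNC(=O)c1nn(-c2ccc(F)cc2)c(OC[C@@H](O)C[C@@H](O)CC(=O)O)c1C(C)C` — 17 nM in an assay on microsomes from liver for inhibition of 3-hydroxy-3-methylglutaryl-coenzyme A reductase (Rattus norvegicus); on this read-out higher numbers stand for weaker inhibition and lower numbers for stronger inhibition
Compound 2: `COc1ccccc1CNC(=O)c1nn(-c2ccc(F)cc2)c(OC[C@@H](O)C[C@@H](O)CC(=O)O)c1C(C)C` — 22 nM in this assay
Compound 3: `CC(C)c1c(C(=O)N(C)Cc2cccc(C(F)(F)F)c2)nn(-c2ccc(F)cc2)c1OC[C@@H](O)C[C@@H](O)CC(=O)O` — 31 nM in this assay

Compound 3 gives the highest of the three numbers in this assay, but its separation from compound 2 and from compound 1 is within the scatter, so the three compounds cannot be ranked against one another on these figures. Going by the values given here, the only single-point step among the measured compounds is a 1.3-fold higher number from compound 1 to compound 2 (0.11 log units; within the scatter), a change on the aromatic ring of the benzyl amide of compound 1 that left the number essentially where it was.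

Compound 4, `CC(C)c1c(C(=O)N(C)Cc2ccc(F)cc2)nn(-c2ccc(F)cc2)c1OC[C@@H](O)C[C@@H](O)CC(=O)O`, is reached from compound 3 by one change: 4-fluorophenyl in place of 3-(trifluoromethyl)phenyl on a saturated chain carbon bound to an amide-type nitrogen. Among the compounds with values here, no measured step covers exactly this exchange. The step from compound 1 to compound 2 is the closest point of comparison, since it also alters only a substituent on that same benzyl ring, and it stayed within the scatter. Within the data shown here, compounds 1 and 2 carry their benzyl groups on an amide with a hydrogen rather than a methyl, so their values show only that such ring substituents have so far made little difference across the shared core.

Compound 4 is therefore expected to stay close to compound 3, with a step of a 1.0-fold lower number from compound 3 to compound 4 (0.01 log units; within the scatter) that lies within the scatter, because the comparable step a 1.3-fold higher number from compound 1 to compound 2 (0.11 log units; within the scatter) was also flat. The estimate for compound 4 in this assay is 30 nM, with a range from 12 nM to 75 nM.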

Compound 4, half-maximal inhibitory concentration: 18 nM
Beside the measured number, compound 4's estimate is 1.7-fold (0.22 log units) above it, and the stated range covers the measured number.
By their numbers in this assay, from the lowest: compounds 1, 4, 2 and 3 (each within the scatter of the next).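

In this assay, exchanging 3-(trifluoromethyl)benzyl for 4-fluorobenzyl on the amide-type nitrogen gives a 1.7-fold lower number from compound 3 to compound 4 (0.24 log units; within the scatter) and so stays within the scatter, which extends the flat picture from the amide hydrogen compounds to the series carrying a methyl on that nitrogen, even for a group with fewer heavy atoms and a different substituent. Going by these compounds alone, the two remaining steps, a 1.2-fold lower number from compound 2 to compound 4 (0.09 log units; within the scatter) and a 1.1-fold higher number from compound 1 to compound 4 (0.02 log units; within the scatter), also stay within the scatter, but each alters the benzyl substituent and the amide methyl together, so they show only that the combined change leaves the number within the scatter, not what either part does alone. Nothing at hand bears on why these changes leave the number within the scatter.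

The compounds shown do not separate the amide methyl from the benzyl substituent, so the contribution of that methyl alone remains open. From the compounds shown here alone, it also remains open whether this tolerance would hold for a carboxylic acid or an amine on the benzyl ring, or for a longer chain in place of the benzyl carbon.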